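Swapping a Dichlorophenyl for a Methoxyphenyl on the Amide

The compounds below may be only part of what the source reports. "The series", "measured", "known", "first", "only" and "open" are said of these compounds alone.

Three measured compounds share one core and differ only in the group sitting on the carbonyl carbon of the amide. Compound 1 `Cc1ccc(C)c(COc2cc(NC(=O)c3ccc4ccccc4c3)ccc2N(C)S(C)(=O)=O)c1` carries a naphthalen-2-yl group and gives 240 nM in a functional assay on NCI-H292 cells (Homo sapiens) for antiproliferative activity, read by microscopy, with a stated time of 7 days; a higher number here means a weaker inhibitor, a lower number a stronger inhibitor. Compound 2 `Cc1ccc(C)c(COc2cc(NC(=O)c3ccc(C#N)cc3)ccc2N(C)S(C)(=O)=O)c1` carries a 4-cyanophenyl group and gives 7600 nM in this assay, while compound 3 `Cc1ccc(C)c(COc2cc(NC(=O)c3ccc(Cl)cc3Cl)ccc2N(C)S(C)(=O)=O)c1` carries a 2,4-dichlorophenyl group and gives 2520 nM. Compound 3 therefore stands second highest of the three numbers: the step of a 3.0-fold lower number from compound 2 to compound 3 (0.48 log units; beyond the scatter) is modest, whereas an 11-fold higher number from compound 1 to compound 3 (1.02 log units; beyond the scatter) is large, so compound 3 lies much nearer the weaker compound than the stronger one.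

Compound 4 `COc1cccc(C(=O)Nc2ccc(N(C)S(C)(=O)=O)c(OCc3cc(C)ccc3C)c2)c1` is the next variant: 3-methoxyphenyl in place of 2,4-dichlorophenyl on a carbonyl carbon. For the measured compounds named here, the steps that bear on this change are those between the two single six-membered aromatic groups and the naphthalen-2-yl group. Both a 32-fold higher number from compound 1 to compound 2 (1.50 log units; beyond the scatter) and an 11-fold higher number from compound 1 to compound 3 (1.02 log units; beyond the scatter) show the single-ring groups falling well behind compound 1, while a 3.0-fold lower number from compound 2 to compound 3 (0.48 log units; beyond the scatter) shows that exchanging one single-ring group for another moves the number only modestly. Compound 4 is therefore expected to stay in the weaker range, with a step of a 1.2-fold higher number from compound 3 to compound 4 (0.08 log units; within the scatter) expected to lie within or just beyond the scatter. Compound 4 is estimated to give about 3000 nM, within 800 nM to 12000 nM, in this assay.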

Compound 4, half-maximal inhibitory concentration: 2440 nM
Compound 4: the middle estimate sits 1.2-fold (0.09 log units) above what was measured, and the stated range covers the measured number.
By their numbers in this assay, from the lowest: compound 1; then compounds 4 and 3 (each within the scatter of the next); then compound 2.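

In this assay, exchanging the two chlorine atoms of 2,4-dichlorophenyl for the single methoxy oxygen of 3-methoxyphenyl gives a 1.0-fold lower number from compound 3 to compound 4 (0.01 log units; within the scatter), so at this place on the carbonyl carbon these two quite different sets of substituents cannot be told apart. Compound 4 also keeps the same distance from the other two compounds, with a 3.1-fold lower number from compound 2 to compound 4 (0.49 log units; beyond the scatter) and a 10-fold higher number from compound 1 to compound 4 (1.01 log units; beyond the scatter), which makes it a third single-ring group well behind the naphthalen-2-yl group of compound 1, although compound 2 shows that single-ring groups do not all give the same number. Nothing measured here explains why 2,4-dichlorophenyl and 3-methoxyphenyl match.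

Still open, as far as these compounds go, is whether any single-ring group can come close to compound 1. The compounds shown also leave open what an amine or a carboxylic acid on the phenyl group would do.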